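Working notes: from compound 2 to compound 3

The source may report more compounds than this note shows. Statements on the series, on what has been measured and on what is new or still open speak of the compounds shown alone.

Measured in a physicochemical assay for lipophilicity, at pH 7.4; a higher number here means a more lipophilic compound, a lower number a more polar compound:
- compound 1 `Cc1cc(N[C@H](CCCCNCc2cccc(F)c2)C(=O)NO)cc(C)c1F`: < 3 (a limit)
- compound 2 `Cc1ccc(CNCCCC[C@@H](Nc2cc(C)c(F)c(C)c2)C(=O)NO)cc1`: < 3 (a limit)

Compound 2 is known only as a limit, < 3, and no number exists for it. Compound 3 `Cc1cc(N[C@H](CCCCNCc2ccc(C(C)(C)C)cc2)C(=O)NO)cc(C)c1F` differs by tert-butyl in place of methyl on an aromatic carbon, with tert-butyl in place of methyl on an aromatic carbon, para to a large group. Among the compounds with values here, the only measured step, a step that the two limits leave unreadable from compound 1 to compound 2, gives no size to carry over. The expectation therefore rests on the structural change alone. An upward move in this assay is expected, estimated as a step that the limit leaves unreadable from compound 2 to compound 3. For compound 3 the expected value is 2.8, with an estimated range of 2.1 to 3.6.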

Compound 3, distribution coefficient: < 3
Compound 3 gave a limit, no number; the forecaster's own chance of this, stated with the estimate: 50%; the middle value does not contradict the limit.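

Compound 3 is a limit in this assay, as are compound 1 and compound 2, so no new step can be read among them: the limit of < 3 in this assay, at which 3 of the 3 values shown sit.

The compounds shown leave open where each actually lies in this assay, and whether 3-fluorophenyl, 4-methylphenyl and 4-(tert-butyl)phenyl differ there at all.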